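Extending the hydroxycarbamoyl chain on a shared core

This account rests on a few compounds, and the source may have more. Where it says the series, first, only, none or still open, it means among the compounds named here.

Compound 1 `O=C(CCCOC(=O)c1ccc2c(c1)no[n+]2[O-])NO`: 13000 nM
Compound 2 `O=C(CCCCCOC(=O)c1ccc2c(c1)no[n+]2[O-])NO`: 33400 nM

In a functional assay on U-937 cells (Homo sapiens) for inhibition, read by MTT assay, with a stated time of 48 h (a lower number here means a stronger inhibitor, a higher number a weaker inhibitor), compound 1 has the lower of the two numbers, and so is the stronger inhibitor of the pair. For the measured compounds named here, the only measured step, a 2.6-fold higher number from compound 1 to compound 2 (0.41 log units; beyond the scatter), is modest but beyond the scatter. Compound 3 `O=C(CCCCCCCOC(=O)c1ccc2c(c1)no[n+]2[O-])NO` keeps the core of compound 1 and carries 4-(hydroxycarbamoyl)butyl in place of hydroxycarbamoyl on a saturated chain carbon, three bonds along the chain from an oxygen next to a carbonyl group. Compound 2 carries 2-(hydroxycarbamoyl)ethyl at that same place, so its step of a 2.6-fold higher number from compound 1 to compound 2 (0.41 log units; beyond the scatter) is the one that bears on this change. One step is thin evidence, and no longer chain has been measured. The expected step in this assay, upward and of similar or somewhat larger size, is a 3.1-fold higher number from compound 1 to compound 3 (0.49 log units; beyond the scatter). For compound 3 the estimated value is 40000 nM, with an expected range of 12000 nM to 100000 nM.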

Compound 3, half-maximal inhibitory concentration: 11900 nM
Compound 3: middle estimate off by 3.4-fold (0.53 log units), on the high side; measured number below the stated range.
By their numbers in this assay, from the lowest: compounds 3 and 1 (each within the scatter of the next); then compound 2.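

In this assay the change to 4-(hydroxycarbamoyl)butyl gives a 1.1-fold lower number from compound 1 to compound 3 (0.04 log units; within the scatter) and so does not extend the upward step seen with 2-(hydroxycarbamoyl)ethyl at this place: compound 3 and compound 1 cannot be told apart. The middle chain instead stands apart, with a 2.8-fold lower number from compound 2 to compound 3 (0.45 log units; beyond the scatter) in the same assay, so among these three compounds the number does not rise steadily with chain length, and compound 3 goes against any such pattern. Nothing available here accounts for this turn. From the compounds shown here alone, it remains open whether a longer chain at this place would keep the number at the level of compound 3 or raise it again. Going by these compounds, it is also open how a carboxylic acid in place of the hydroxycarbamoyl end would read on the shared core.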